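Swapping 2-isopropylphenyl for 4-(tert-butyl)phenyl on the shared core

This account rests on a few compounds, and the source may have more. Where it says the series, first, only, none or still open, it means among the compounds named here.

compound 1 `CN1CCN(c2ccc(Nc3ncc(Cl)c(Nc4ccccc4)n3)nc2)CC1` gives 37400 nM
compound 2 `CN1CCN(c2ccc(Nc3ncc(Cl)c(NCc4ccco4)n3)nc2)CC1` gives 11000 nM
compound 3 `CC(C)c1ccccc1Nc1nc(Nc2ccc(N3CCN(C)CC3)cn2)ncc1Cl` gives 4090 nM

These three values come from a functional assay on MDA-MB-231 cells (Homo sapiens) for inhibition, read by CCK-8 assay, with a stated time of 48 h (on this read-out lower numbers stand for stronger inhibition of growth and higher numbers for weaker inhibition of growth), and compound 3 has the lowest number among them. Both gaps to it lie beyond the scatter, as a 9.1-fold lower number from compound 1 to compound 3 (0.96 log units; beyond the scatter) and a 2.7-fold lower number from compound 2 to compound 3 (0.43 log units; beyond the scatter) show.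

Compound 4 `CN1CCN(c2ccc(Nc3ncc(Cl)c(Nc4ccc(C(C)(C)C)cc4)n3)nc2)CC1` has not yet been measured. It differs from compound 3 in one place (4-(tert-butyl)phenyl in place of 2-isopropylphenyl on a nitrogen on an aromatic ring), with 4-(tert-butyl)phenyl in place of 2-isopropylphenyl on a nitrogen on an aromatic ring.

The most relevant measured step is a 9.1-fold lower number from compound 1 to compound 3 (0.96 log units; beyond the scatter) and it is modest. It shows that isopropyl in place of hydrogen on an aromatic carbon went with a lower number. The step of a 3.4-fold lower number from compound 1 to compound 2 (0.53 log units; beyond the scatter) bears less, since it replaces the phenyl with (furan-2-yl)methyl. For the measured compounds named here, compound 4 also keeps a phenyl carrying an alkyl group, but no measured compound has 4-(tert-butyl)phenyl, so the data cannot show whether the lower number carries over in full.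

The expected change is a 1.5-fold higher number from compound 3 to compound 4 (0.17 log units; within the scatter) and so stays within the scatter, leaning slightly towards a higher number. For compound 4 the expected value is 6000 nM with an estimated range from 2000 nM to 17000 nM at this stage.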

Compound 4, concentration for 50% growth inhibition: 16200 nM
Beside the measured number, compound 4's estimate is 2.7-fold (0.43 log units) below it; low and high end bracket the measured number.
By their numbers in this assay, from the lowest: compound 3; then compounds 2 and 4 (each within the scatter of the next); then compound 1.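

In this assay, the identity of the alkyl-bearing phenyl on a nitrogen on an aromatic ring matters: 4-(tert-butyl)phenyl gives up part of what 2-isopropylphenyl gained, with a 4.0-fold higher number from compound 3 to compound 4 (0.60 log units; beyond the scatter) beyond the scatter, so an alkyl group on the phenyl does not by itself set the number. The tert-butyl group still goes with a gain over the plain phenyl, seen in a 2.3-fold lower number from compound 1 to compound 4 (0.36 log units; beyond the scatter), while a 1.5-fold higher number from compound 2 to compound 4 (0.17 log units; within the scatter) means that 4-(tert-butyl)phenyl and (furan-2-yl)methyl cannot be told apart in this read-out. Nothing available here accounts for these differences.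

The change from 2-isopropylphenyl to 4-(tert-butyl)phenyl alters both the alkyl group and where it sits on the phenyl, so the compounds shown cannot say which of the two goes with the higher number. They also leave open how this position would respond to a phenyl carrying an amine, a carboxylic acid or a longer alkyl chain, and whether the order seen here would hold on a different core.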